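Alkoxy variation on the aminoquinoline ether series

The source may hold more compounds than are shown below. What is called first, only, known or untested is meant among the compounds shown, and "the series" means these compounds.

Within the data shown here, compound 2 `CCCCOc1cccc2ccc(N)nc12` gives 789 nM in an assay on cells with melanin-concentrating hormone receptor 1 (Homo sapiens) as the target, read by radioligand binding (on this read-out lower numbers stand for stronger inhibition and higher numbers for weaker inhibition), the lowest of the two numbers so far. Among the measured compounds shown here, its neighbour in the set, compound 1 `CC1CC1COc1cccc2ccc(N)nc12`, gives 1640 nM in this assay; the step of a 2.1-fold lower number from compound 1 to compound 2 (0.32 log units; beyond the scatter) is the only measured step, with propyl in place of 2-methylcyclopropyl on a saturated chain carbon bound to an oxygen on an aromatic ring. Compound 3 `CC1CCC(Oc2cccc3ccc(N)nc23)C1` is not yet measured. It differs from compound 2 by 3-methylcyclopentyl in place of butyl on an oxygen on an aromatic ring. For the measured compounds named here, the one step available runs the other way, from a small ring with a methyl toward an open chain, and was modest in size; a return to a ring, now five-membered and bearing a methyl, is therefore expected to give a modest weakening at most, a 1.5-fold higher number from compound 2 to compound 3 (0.18 log units; within the scatter), with a real chance of no shift beyond the scatter. For compound 3 the estimate in this assay is 1200 nM, with a range from 400 nM to 3500 nM.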

Compound 3, half-maximal inhibitory concentration: 823 nM
Compound 3: middle estimate off by 1.5-fold (0.16 log units), on the high side; the range from low to high includes it.
By their numbers in this assay, from the lowest: compounds 2, 3 and 1 (each within the scatter of the next, the first and the last beyond it).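

In this assay the ring placed directly on the oxygen gives a 1.0-fold higher number from compound 2 to compound 3 (0.02 log units; within the scatter) and so stays within the scatter, which means that 3-methylcyclopentyl is tolerated here as well as butyl and an open chain is not needed at this position. The other new step, a 2.0-fold lower number from compound 1 to compound 3 (0.30 log units; within the scatter), is also within the scatter, so the two ring-bearing groups cannot be ordered, and the only separation in the set remains a 2.1-fold lower number from compound 1 to compound 2 (0.32 log units; beyond the scatter), which leaves the earlier gap without a clear link to ring or chain as such. Nothing available explains these readings.

Going by these compounds, whether a longer chain, or an amine or hydroxyl on the chain, would move the number at this oxygen remains open. The contribution of the methyl is also open, as unsubstituted cyclopentyl is not among the compounds shown.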